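Terminal amide substituent in a bis-methoxyphenyl amide series

The source may hold more compounds than are shown below. What is called first, only, known or untested is meant among the compounds shown, and "the series" means these compounds.

Measured compounds:
Compound 1 `COc1ccc(-c2cc(NC(=O)COCC(=O)NCC(=O)NC(C)(C)C)nc(-c3ccc(OC)cc3)n2)cc1` — in an assay on HeLa cells for displacement of a labelled ligand from adenosine receptor A3 (Homo sapiens), read by fluorescence polarization, with a stated time of 30 min (on this read-out higher numbers stand for weaker inhibition and lower numbers for stronger inhibition), compound 1 gives 19700 nM.
Compound 2 `COc1ccc(-c2cc(NC(=O)COCC(=O)NCC(=O)NC3CCCCC3)nc(-c3ccc(OC)cc3)n2)cc1` — in this assay compound 2 gives 21400 nM.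
Compound 3 `COc1ccc(-c2cc(NC(=O)COCC(=O)N(C)CC(=O)NC(C)(C)C)nc(-c3ccc(OC)cc3)n2)cc1` — in this assay compound 3 gives 19400 nM.

Compound 3 has the lowest of the three numbers, but its separation from the others is small: a 1.0-fold lower number from compound 1 to compound 3 (0.01 log units; within the scatter) and a 1.1-fold lower number from compound 2 to compound 3 (0.04 log units; within the scatter), both within the scatter, so no ordering among compounds 1, 2 and 3 can be read from these data.

Compound 4 `COc1ccc(-c2cc(NC(=O)COCC(=O)N(C)CC(=O)NCc3ccccc3)nc(-c3ccc(OC)cc3)n2)cc1` has not yet been measured. It differs from compound 3 in one place: benzyl in place of tert-butyl on an amide-type nitrogen. The same nitrogen has been varied once before in this set, in the step of a 1.1-fold higher number from compound 1 to compound 2 (0.04 log units; within the scatter), where cyclohexyl replaced tert-butyl without any shift beyond the scatter. Methylation of the inner amide nitrogen, a 1.0-fold lower number from compound 1 to compound 3 (0.01 log units; within the scatter), likewise left the number unchanged within the scatter. Both steps suggest this end of the chain tolerates variation without moving the read-out, though benzyl itself has not been tried.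

Compound 4 is therefore expected to show a 1.0-fold higher number from compound 3 to compound 4 (0.01 log units; within the scatter) in this assay, that is, no step beyond the scatter. The estimate for compound 4 is 20000 nM, with a range from 8000 nM to 50000 nM.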

Compound 4, inhibition constant: 40100 nM
For compound 4 the middle estimate is 2.0-fold (0.30 log units) below the measured one; low and high end bracket the measured number.
By their numbers in this assay, from the lowest: compounds 3, 1, 2 and 4 (each within the scatter of the next, the first and the last beyond it).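

In this assay, the substituent on the terminal amide nitrogen now shows an effect beyond the scatter: a 2.1-fold higher number from compound 3 to compound 4 (0.32 log units; beyond the scatter), a modest shift towards weaker inhibition with benzyl in place of tert-butyl. The earlier change at this nitrogen, a 1.1-fold higher number from compound 1 to compound 2 (0.04 log units; within the scatter), stayed within the scatter, so the tolerance suggested by cyclohexyl does not extend unchanged to benzyl, which brings in one six-membered aromatic ring of carbon only and has 7 heavy atoms against 4 for tert-butyl. No accompanying measurement bears on the reason for this step.

The compounds shown leave open whether the shift follows the aromatic ring itself or the carbon that links it to the nitrogen, a question that phenyl or 2-phenylethyl on the same nitrogen would address, while a pyridylmethyl group or a terminal carboxylic acid would extend the range of groups compared. Going by these compounds, it also remains open whether benzyl has the same effect when the inner amide nitrogen carries hydrogen, as in compound 1, rather than the methyl of compound 3.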